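The source may report more compounds than this note shows. Statements on the series, on what has been measured and on what is new or still open speak of the compounds shown alone.

Measured compounds:
compound 1 `CCCc1c(COc2ccc(C(=O)C(C)(C)Cc3nnn[nH]3)cc2)ccc(C(C)=O)c1O`, 10.8 mg/kg
compound 2 `CCCCc1c(COc2ccc(C(=O)CCCCC(=O)O)cc2)ccc(C(C)=O)c1O`, 9.1 mg/kg

In an in vivo functional assay on the whole organism (Rattus norvegicus) with cysteinyl leukotriene receptor (Homo sapiens) as the target (on this read-out lower numbers stand for an effect already at smaller amounts and higher numbers for an effect only at larger amounts of compound), compound 1 gives 10.8 mg/kg, the higher of the two numbers; compound 2, with its open-chain acid on the carbonyl carbon, gives 9.1 mg/kg, and the two values lie within the usual scatter of each other, so neither stands apart.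

Compound 3 `CCCc1c(COc2ccc(C(=O)CCCCc3nnn[nH]3)cc2)ccc(C(C)=O)c1O` differs from compound 1 in one place: 4-(1H-tetrazol-5-yl)butyl in place of 1-((1H-tetrazol-5-yl)methyl)-1-methylethyl on a carbonyl carbon. The branching at the carbonyl carbon is undone and the tetrazole is carried on an unbranched chain, so that compound 3 comes to resemble compound 2 in the shape of its side chain while keeping the tetrazole of compound 1.

No step between measured compounds is shown for such a change. Given that compound 2 gives 9.1 mg/kg and compound 1 gives 10.8 mg/kg, compound 3 is expected to fall close to both, with a step from a 1.4-fold lower number from compound 1 to compound 3 (0.16 log units; within the scatter) no larger than the scatter, if anything toward a smaller dose. Compound 3 is therefore estimated at 7.5 mg/kg, within 3 mg/kg to 18 mg/kg.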

Compound 3, dose for half-maximal effect: 2.4 mg/kg
Estimate against measurement, compound 3: 3.1-fold (0.49 log units) above, outside the stated range (below it).
By their numbers in this assay, from the lowest: compound 3; then compounds 2 and 1 (each within the scatter of the next).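

With the same atoms joined differently, 4-(1H-tetrazol-5-yl)butyl in place of 1-((1H-tetrazol-5-yl)methyl)-1-methylethyl on a carbonyl carbon gives a 4.5-fold lower number from compound 1 to compound 3 (0.65 log units; beyond the scatter) in this assay. For the compounds shown here, this shows that the response at this position depends on how the tetrazole is attached to the carbonyl carbon, and not only on the tetrazole being present, which the earlier compounds, differing from each other in more than one place, could not show. Nothing available here accounts for the size of this step.

Going by these compounds, the branching and the chain carrying the tetrazole change together in this step, so their separate shares remain open. Also open, on these data alone, is how a single methyl branch on the butyl chain, or a longer chain such as pentyl, would read out here.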